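The source may report more compounds than this note shows. Statements on the series, on what has been measured and on what is new or still open speak of the compounds shown alone.

Compound 3, with the structure `COc1ccc(OCc2ccc(C(C)(C)NC(=O)c3ccc([N+](=O)[O-])o3)cc2)cc1`, is the starting point here. In an ADME assay on Vero cells (Chlorocebus sabaeus) for cytotoxicity, read by MTT assay, with a stated time of 48 h (on this read-out lower numbers stand for higher toxicity in this test and higher numbers for lower toxicity in this test), compound 3 gives > 120000 nM, which is a limit of the test and not a number. Two companions share its core. Compound 1, `CC(C)(C)c1ccc(C(C)(C)NC(=O)c2ccc([N+](=O)[O-])o2)cc1`, gives in this assay > 150000 nM, again a limit rather than a number. Compound 2, `CC(C)(NC(=O)c1ccc([N+](=O)[O-])o1)c1ccc(-c2ccc(Cl)cc2)cc1`, gives in this assay > 140000 nM, also a limit. Because (the limit of > 120000 nM in this assay, at which 1 of the 3 values shown sits), the limit of > 140000 nM in this assay, at which 1 of the 3 values shown sits, and the limit of > 150000 nM in this assay, at which 1 of the 3 values shown sits, each mark a limit, the steps a step that the two limits leave unreadable from compound 1 to compound 2, a step that the two limits leave unreadable from compound 1 to compound 3 and a step that the two limits leave unreadable from compound 2 to compound 3 cannot be read for size. Compound 4, `CC(C)(NC(=O)c1ccc([N+](=O)[O-])o1)c1ccc(COc2ccccc2C(F)(F)F)cc1`, has not yet been measured; it differs from compound 3 by 2-(trifluoromethyl)phenyl in place of 4-methoxyphenyl on an oxygen on a saturated carbon. None of the three measured steps bears readably on this change, so no direction can be drawn from them. For compound 4 the step that the limit leaves unreadable from compound 3 to compound 4 is expected to be none beyond the scatter. Compound 4 is therefore estimated at 150000 nM, in a range from 70000 nM to 300000 nM, most likely reported once more as a limit.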

Compound 4, half-maximal cytotoxic concentration: 14000 nM
Compound 4: middle estimate off by 11-fold (1.03 log units), on the high side; the whole stated range lies above it.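

In this assay, the group on this oxygen does matter: 2-(trifluoromethyl)phenyl in place of 4-methoxyphenyl gives an at least 8.5-fold lower number from compound 3 to compound 4 (0.93 log units; beyond the scatter), which here means higher toxicity in this test. The earlier compounds shown here could not show this, as all of them stand at limits and the steps among them cannot be read, whereas compound 4 alone of the four carries a real number. The step is only a minimum because compound 3 stands at a limit and not at a number: the limit of > 120000 nM in this assay, at which 1 of the 4 values shown sits.

Still open, from the compounds shown here alone, is which part of the change counts, as the trifluoromethyl group arrives and the methoxy group leaves in one move. Plain phenyl, 2-methoxyphenyl or 4-(trifluoromethyl)phenyl on the same oxygen would help to pull these parts apart.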